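The compounds below may be only part of what the source reports. "The series", "measured", "known", "first", "only" and "open" are said of these compounds alone.

Among the compounds with values here, compound 1 `O=C1C(Nc2ccc(C(F)(F)F)cc2)=CC(=O)c2c1nc1n2[C@H]2OC[C@@H](O)[C@H]2OC1` is one of three compounds measured in a functional assay on MGC-803 cells (Homo sapiens) for inhibition, read by sulforhodamine B assay; a higher number here means a weaker inhibitor, a lower number a stronger inhibitor. Compound 1 gives 1860 nM. Compound 2 `COc1ccc(NC2=CC(=O)c3c(nc4n3[C@H]3OC[C@@H](O)[C@H]3OC4)C2=O)cc1` carries methoxy in place of trifluoromethyl on an aromatic carbon, and in this assay compound 2 gives 2150 nM. This change made a 1.2-fold higher number from compound 1 to compound 2 (0.06 log units; within the scatter). Compound 3 `O=C1C=C(Nc2ccc(C(F)(F)F)cc2)C(=O)c2c1nc1n2[C@H]2OC[C@@H](O)[C@H]2OC1` is built from the same atoms as compound 1, joined differently; the difference between the two cores is not broken down here. In this assay compound 3 gives 2820 nM. The values of compound 1, compound 2 and compound 3 all lie within the usual scatter of one another, so none of the three can be set apart from the others.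

Compound 4 `COc1ccc(NC2=CC(=O)c3nc4n(c3C2=O)[C@H]2OC[C@@H](O)[C@H]2OC4)cc1` has not yet been measured in this assay. It differs from compound 3 by methoxy in place of trifluoromethyl on an aromatic carbon, the same change, made at the same place, that turns compound 1 into compound 2. For compound 4 the expected step is a 1.2-fold higher number from compound 3 to compound 4 (0.07 log units; within the scatter). This expectation rests on compound 1 and compound 2, because a 1.2-fold higher number from compound 1 to compound 2 (0.06 log units; within the scatter) and the same change on the core of compound 3 is taken to behave alike, with nothing in the data pointing the other way. Compound 4 is therefore estimated at 3300 nM in this assay, with a likely range from 1600 nM to 6800 nM.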

Compound 4, half-maximal inhibitory concentration: 1680 nM
The estimate for compound 4 lay 2.0-fold (0.29 log units) above the measured number; low and high end bracket the measured number.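

In this assay, the step for methoxy in place of trifluoromethyl on the core of compound 3 is a 1.7-fold lower number from compound 3 to compound 4 (0.22 log units; within the scatter), which leaves this pair, like the earlier pair, within the usual scatter. The two steps carry opposite signs as printed, but that difference is not one the data can separate: the same change on two cores in this assay, a 1.2-fold higher number (0.06 log units; within the scatter) from compound 1 to compound 2 and a 1.7-fold lower number (0.22 log units; within the scatter) from compound 3 to compound 4, 1.9-fold (0.29 log units) apart, within the scatter of two such steps. This shows that, for this one change, nothing distinguishes the two cores in this assay and that the earlier step was a fair guide to the later one, but it does not show that the two cores would respond alike to any other change, and two small steps cannot establish that the change has no effect at all.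

Only 4-(trifluoromethyl)phenyl and 4-methoxyphenyl appear among the compounds shown, so it remains open whether another group in the same place, such as a chlorine, an amine, a carboxylic acid or a longer chain, would move the number beyond the scatter on either core. Going by these compounds, it also remains open whether such a group would give different steps on the two cores, and whether the same would hold outside this single cell assay.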